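Cyclopentenyl in Place of Propyl on the Shared Core

This account rests on a few compounds, and the source may have more. Where it says the series, first, only, none or still open, it means among the compounds named here.

Measured compounds:
Compound 1: `Cc1c(C(=O)Nc2ccc(Oc3ncnc4[nH]cc(-c5ccccc5)c34)c(F)c2)c(=O)c2cc(C(C)C)ccc2n1C`, 26 nM
Compound 2: `CCCc1ccc2c(c1)c(=O)c(C(=O)Nc1ccc(Oc3ncnc4[nH]cc(-c5ccccc5)c34)c(F)c1)c(C)n2C`, 61 nM

Both compounds were tested in an assay on isolated protein for inhibition of tyrosine-protein kinase receptor UFO (Homo sapiens), read by FRET and Z'-LYTE, with a stated time of 1.5 h; a lower number here means a stronger inhibitor, a higher number a weaker inhibitor. Compound 1 gives 26 nM, and compound 2 gives 61 nM. Among the two numbers, compound 2 has the higher one, so it is the weaker inhibitor of the pair; the only measured step, a 2.3-fold higher number from compound 1 to compound 2 (0.37 log units; beyond the scatter), is the one that separates them, and it comes from swapping a branched three-carbon group for a straight one at the same spot on the core.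

Compound 3 is `Cc1c(C(=O)Nc2ccc(Oc3ncnc4[nH]cc(-c5ccccc5)c34)c(F)c2)c(=O)c2cc(C3=CCCC3)ccc2n1C`. Relative to compound 2 the change is cyclopent-1-en-1-yl in place of propyl on an aromatic carbon. The step that bears on it is a 2.3-fold higher number from compound 1 to compound 2 (0.37 log units; beyond the scatter), since it changed the same position: moving from isopropyl to propyl cost a modest amount. The cyclopent-1-en-1-yl group, like isopropyl, is joined to the ring through a carbon that carries two further carbons, so some of that loss may be recovered, though the new group is larger and nothing measured here shows such a ring.

For compound 3 the expected step in this assay is a 1.7-fold lower number from compound 2 to compound 3 (0.24 log units; within the scatter), a modest improvement. Compound 3 is therefore estimated at 35 nM, with a range from 12 nM to 100 nM.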

Compound 3, half-maximal inhibitory concentration: 3320 nM
The estimate for compound 3 lay 95-fold (1.98 log units) below the measured number; measured number above the stated range.
By their numbers in this assay, from the lowest: compound 1; then compound 2; then compound 3.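

In this assay this position turns out to be far less forgiving than the two open-chain groups suggested: isopropyl and propyl differ only modestly, whereas cyclopent-1-en-1-yl in place of propyl gives a 54-fold higher number from compound 2 to compound 3 (1.74 log units; beyond the scatter) and in place of isopropyl gives a 130-fold higher number from compound 1 to compound 3 (2.11 log units; beyond the scatter) on the same shared core. Resemblance to isopropyl at the carbon joined to the aromatic ring therefore does not carry the potency over, so that single feature is a poor guide to what this spot accepts. Compound 3 differs from compound 2 in several ways at once, with a ring, a double bond outside the aromatic rings and a larger carbon count all entering together, and no measurement shown gives a reason for the loss.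

Which of those features matters remains open, and cyclopentyl, the same ring without its double bond, would be the direct way to separate the ring from the double bond. Also open, from the compounds shown here alone, is how a small ring such as cyclopropyl or a longer chain such as butyl would fare here, which would show where along the range of sizes the numbers begin to climb so steeply.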